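From Urea to Amide at the Shared Core

A few compounds are considered here, and "the series" means these few. Any claim that something is new, unique, unknown or untested is made for them only; others in the source may bear on it.

Within the data shown here, compound 2 `COc1cc(-c2nn(-c3cccc(NC(=O)Nc4cccc(C(F)(F)F)c4)c3)cc2-c2ccncc2)ccc1Cl` is one of two compounds measured so far. In a functional assay on HCT-116 cells (Homo sapiens) for inhibition, read by sulforhodamine B assay, with a stated time of 48 h (a lower number here means a stronger inhibitor of growth, a higher number a weaker inhibitor of growth), compound 2 gives 900 nM, while compound 1 `COc1cc(-c2nn(-c3cccc(NC(=O)Nc4ccc(Cl)c(Cl)c4)c3)cc2-c2ccncc2)ccc1Cl` gives 1210 nM; the step of a 1.3-fold lower number from compound 1 to compound 2 (0.13 log units; within the scatter) lies within the scatter. Compound 3 `COc1cc(-c2nn(-c3cccc(NC(=O)c4ccc(Cl)c(C(F)(F)F)c4)c3)cc2-c2ccncc2)ccc1Cl` alters the linker instead: 4-chloro-3-(trifluoromethyl)phenyl in place of (3-(trifluoromethyl)phenyl)amino on a carbonyl carbon. Among the measured compounds shown here, no measured step concerns the carbonyl carbon, and the single step available, which swaps the group on the amide-type nitrogen, stayed within the scatter, so the direction of any shift is uncertain and the expected step for compound 3 is a 1.2-fold higher number from compound 2 to compound 3 (0.09 log units; within the scatter). Compound 3 is therefore estimated at 1100 nM, with a range from 350 nM to 3500 nM.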

Compound 3, concentration for 50% growth inhibition: 2490 nM
Compound 3: the middle estimate sits 2.3-fold (0.35 log units) below what was measured; the measured number falls inside the stated range.
By their numbers in this assay, from the lowest: compounds 2 and 1 (each within the scatter of the next); then compound 3.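

Among these compounds, on the carbonyl carbon, 4-chloro-3-(trifluoromethyl)phenyl in place of (3-(trifluoromethyl)phenyl)amino gives the first change beyond the scatter in this assay (a 2.8-fold higher number from compound 2 to compound 3 (0.44 log units; beyond the scatter)). Replacing (3,4-dichlorophenyl)amino with the same group points the same way (a 2.1-fold higher number from compound 1 to compound 3 (0.31 log units; beyond the scatter)), so at this position both amino groups give stronger growth inhibition than the group without the amino nitrogen. No measurement here explains this difference.

The swap from compound 2 to compound 3 removes the amino nitrogen and adds a chlorine together, so their separate contributions remain unresolved. Also open, as far as these compounds go, is how a carboxylic acid or a piperazine on the far end of this carbonyl carbon would behave.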